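Opening a Pyrrolidine Ring into a Diamine Chain

This account rests on a few compounds, and the source may have more. Where it says the series, first, only, none or still open, it means among the compounds named here.

Compound 1 `N[C@@H]1CCN(c2cc3c(cc2F)c(=O)c(C(=O)O)cn3Cc2ccc(-c3ccccc3)cc2)C1` — 63600 nM
Compound 2 `COc1c(N2CC[C@@H](CO)C2)c(F)cc2c(=O)c(C(=O)O)cn(Cc3ccc(-c4ccccc4)cc3)c12` — > 200000 nM

In an assay on isolated protein for inhibition of DNA topoisomerase 1 (Homo sapiens), with a stated time of 15 min (a higher number here means a weaker inhibitor, a lower number a stronger inhibitor), compound 1 gives 63600 nM. For compound 2 only a limit is known, > 200000 nM, and it stands at the limit of > 200000 nM in this assay, at which 1 of the 2 values shown sits. Compound 3 `CNCCCNc1c(F)cc2c(=O)c(C(=O)O)cn(Cc3ccc(-c4ccccc4)cc3)c2c1OC` differs from compound 2 in one place: (3-(methylamino)propyl)amino in place of 3-(hydroxymethyl)pyrrolidin-1-yl on an aromatic carbon. For the measured compounds named here, no step between measured compounds is known, so no direction can be drawn from the data; a change no larger than the usual scatter is expected. Compound 3 is estimated at 120000 nM, with a range from 40000 nM to 300000 nM. The step of an at least 1.6-fold lower number from compound 2 to compound 3 (0.22 log units; that floor lies within the scatter) is the one expected.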

Compound 3, half-maximal inhibitory concentration: 101000 nM
Beside the measured number, compound 3's estimate is 1.2-fold (0.07 log units) above it; the measured number falls inside the stated range.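

In this assay, the change at this aromatic carbon, ortho to a fluoro group and ortho to a methoxy group, gives an at least 1.9-fold lower number from compound 2 to compound 3 (0.29 log units; that floor lies within the scatter). That floor is no proven gain, but compound 3 shows that an open chain with no ring at this position can give a measured number. Compound 2 remains only a limit, so the true size of the step stays unknown: the limit of > 200000 nM in this assay, at which 1 of the 3 values shown sits.

Still open, on these data alone, is whether opening the ring or swapping the hydroxymethyl oxygen for an amine nitrogen matters more. A (3-hydroxypropyl)amino chain or a longer diamine chain at this carbon could separate the two.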